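Halogen swap on the hydroxyphenyl ring: outlook for compound 3

This account rests on a few compounds, and the source may have more. Where it says the series, first, only, none or still open, it means among the compounds named here.

For the measured compounds named here, the two measured members share one core. Compound 1 `CC(C)(C)C1=NN(c2ccc(Cl)cc2)C(c2cccc(O)c2)C1` carries a 3-hydroxyphenyl on a saturated ring carbon, compound 2 `CC(C)(C)C1=NN(c2ccc(Cl)cc2)C(c2ccc(O)c(F)c2)C1` a 3-fluoro-4-hydroxyphenyl. In an assay on isolated protein for inhibition of protein kinase C zeta type (Homo sapiens), with a stated time of 4 min, tested at 62.5 uM (on this read-out higher numbers stand for more inhibition at the one concentration tested (going by the name of the read-out) and lower numbers for less inhibition), compound 1 gives 95.6% and compound 2 gives 98.5%; the step of a number 2.9 percentage points higher from compound 1 to compound 2 (within the scatter) does not separate them. Of the two numbers, compound 2 holds the top entry with compound 1 nearest, and since that gap is within the scatter the two are effectively indistinguishable. Compound 3 `CC(C)(C)C1=NN(c2ccc(Cl)cc2)C(c2ccc(O)c(Cl)c2)C1` differs from compound 2 by chloro in place of fluoro on an aromatic carbon. Going by the values given here, no measured step exchanges one halogen for another; the only step available, a number 2.9 percentage points higher from compound 1 to compound 2 (within the scatter), is within the scatter and both readings sit level at the high end of the percentage scale. No change beyond the scatter is therefore expected in this assay. Compound 3 is expected to give 97%, in a range from 89% to 100%. The expected step of a number 1.5 percentage points lower from compound 2 to compound 3 (within the scatter) is estimated to stay within the scatter.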

Compound 3, a percentage reported as inhibition, at one concentration (the size of the read-out at that concentration, not a potency): 94.5%
The estimate for compound 3 lay 2.5 percentage points above the measured number; the range from low to high includes it.
By their numbers in this assay, from the lowest: compounds 3, 1 and 2 (each within the scatter of the next).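

In this assay, for the compounds shown here, chloro in place of fluoro on the aromatic carbon ortho to a hydroxy group gives a number 4 percentage points lower from compound 2 to compound 3 (within the scatter) and so offers the first direct halogen exchange at this position, one that does not separate the two compounds. Against the 3-hydroxyphenyl member, the 3-chloro-4-hydroxyphenyl group gives a number 1.1 percentage points lower from compound 1 to compound 3 (within the scatter) and so brings no separation either, leaving all three aryl groups level on this read-out. No supporting evidence bears on this result.

As far as these compounds go, all three readings sit high on the percentage scale at a single concentration, so whether these groups would differ in a true potency measurement stays open. Also open, from the compounds shown here alone, is how an amine, a carboxylic acid or a methoxy group in place of the halogen on this carbon would read.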